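The compounds below may be only part of what the source reports. "The series", "measured", "known", "first", "only" and "open" are said of these compounds alone.

Going by the values given here, in a functional assay on OVCAR-3 cells (Homo sapiens) for inhibition, read by MTT assay, with a stated time of 24 h (on this read-out higher numbers stand for weaker inhibition and lower numbers for stronger inhibition), compound 2 `CC1(C)[C@H]2CC[C@]1(C)N(Cc1cn(-c3ccccc3F)nn1)C(=O)C2` gives 300 nM and holds the higher of the two numbers so far, with compound 1 `CC1(C)[C@H]2CC[C@]1(C)N(Cc1cn(-c3ccccc3C#N)nn1)C(=O)C2` lower at 110 nM in the same read-out. The move to compound 3 `CC1(C)[C@H]2CC[C@]1(C)N(Cc1cn(-c3ccc(F)cc3)nn1)C(=O)C2` is 4-fluorophenyl in place of 2-fluorophenyl on an aromatic nitrogen on the same aromatic nitrogen. Among the compounds with values here, the only measured step (a 2.7-fold higher number from compound 1 to compound 2 (0.44 log units; beyond the scatter)) is modest and concerns a different change, fluoro in place of cyano, so no data yet cover a shift of the fluorine. The expected outcome is a 1.2-fold lower number from compound 2 to compound 3 (0.06 log units; within the scatter) and thus no step beyond the scatter in this assay in either direction. For compound 3 the estimate is 260 nM (expected range 100 nM to 700 nM).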

Compound 3, half-maximal inhibitory concentration: 200 nM
Beside the measured number, compound 3's estimate is 1.3-fold (0.11 log units) above it; the range from low to high includes it.
By their numbers in this assay, from the lowest: compounds 1, 3 and 2 (each within the scatter of the next, the first and the last beyond it).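

In this assay the fluorine shift shows a 1.5-fold lower number from compound 2 to compound 3 (0.18 log units; within the scatter) and so gives no step beyond the scatter for 4-fluorophenyl in place of 2-fluorophenyl on this aromatic nitrogen. The exchange against the nitrile shows a 1.8-fold higher number from compound 1 to compound 3 (0.26 log units; within the scatter) and is also within the scatter, so compound 3 separates from neither compound 1 nor compound 2, though those two stand apart. Nothing available accounts for these steps.

Open, on these data alone, is how 3-fluorophenyl would read at the same nitrogen. Also open, as far as these compounds go, is whether an amine or a carboxylic acid on the phenyl ring would leave this span of values.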